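The compounds below may be only part of what the source reports. "The series", "measured", "known", "first", "only" and "open" are said of these compounds alone.

Measured compounds in the series:

- compound 1, `Cc1ccccc1Nc1nc(C)c(C(=O)/C=C/c2ccccc2)s1`
- compound 2, `Cc1nc(Nc2ccccc2)sc1C(=O)/C=C/c1ccccc1`
- compound 3, `COc1cc(/C=C/C(=O)c2sc(Nc3ccccc3)nc2C)cc(OC)c1OC`

In a functional assay on NCI-H460 cells (Homo sapiens) for cytotoxicity, read by MTT assay (on this read-out lower numbers stand for stronger inhibition and higher numbers for weaker inhibition), compound 1 gives only a limit, > 25000 nM. In this assay compound 2 likewise gives a limit, > 25000 nM. For compound 3 this assay again reports a limit, > 25000 nM. All three values therefore sit on the limit of > 25000 nM in this assay, at which 3 of the 3 values shown sit, and no number is known for any of them.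

Compound 2 and compound 1 differ by methyl in place of hydrogen on an aromatic carbon. The step from compound 2 to compound 1 is a step that the two limits leave unreadable from compound 2 to compound 1. How the core of compound 3 differs from that of compound 2 is not broken down here.

Compound 4, `COc1cc(/C=C/C(=O)c2sc(Nc3ccc(C)cc3)nc2C)cc(OC)c1OC`, is not yet measured in this assay. It differs from compound 3 by methyl in place of hydrogen on an aromatic carbon. This is the same kind of change as from compound 2 to compound 1, though not the same: there the methyl sits ortho to a large group, here para to a large group.

Because compound 3 gives only a limit > 25000 nM in this assay, and because the earlier methyl step is unreadable a step that the two limits leave unreadable from compound 2 to compound 1, the step from compound 3 to compound 4 is expected to be a step that the limit leaves unreadable from compound 3 to compound 4. Compound 4 is thus estimated at 40000 nM, most likely again reported as a limit.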

Compound 4, half-maximal inhibitory concentration: > 25000 nM
Compound 4: a limit, no number; the forecaster's own chance of this, stated with the estimate: 85%; the middle value lies beyond the limit too.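

In this assay compound 4 gives > 25000 nM, a limit and not a number. Compound 3 also gives only a limit, so no step between compound 3 and compound 4 can be read: the limit of > 25000 nM in this assay, at which 4 of the 4 values shown sit.

The compounds shown leave open what size the methyl change has, and whether any compound in the series reaches a measurable value in this assay.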